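The source may hold more compounds than are shown below. What is called first, only, known or untested is meant among the compounds shown, and "the series" means these compounds.

Compound 1 `O=C1COc2ccc(-c3[nH]c(-c4ccc(F)cc4)nc3-c3ccccc3)cc2N1` gives 94.8% in a functional assay on DLD-1 cells (Homo sapiens) for cytotoxicity, read by colorimetric assay and MTT assay, with a stated time of 3 days, tested at 1 uM; a lower number here means a stronger effect, a higher number a weaker effect of the compound at the concentration tested. Compound 2 `O=C1COc2ccc(-c3nn(-c4ccc(Br)cc4)cc3-c3ccccc3)cc2N1` gives 66.4%, and compound 3 `O=C1COc2ccc(-c3nn(-c4ccc(Cl)cc4)cc3-c3ccccc3)cc2N1` gives 61.9%, the lowest of the three numbers, with compound 2 nearest and compound 1 furthest. Among the measured compounds shown here, the only single step seen, a number 4.5 percentage points lower from compound 2 to compound 3 (within the scatter), exchanges one halogen for another on the same ring. Compound 4 `O=C1COc2ccc(-c3nn(-c4cc(Cl)cc(Cl)c4)cc3-c3ccccc3)cc2N1` differs from compound 3 by 3,5-dichlorophenyl in place of 4-chlorophenyl on an aromatic nitrogen. For the measured compounds named here, no measured step covers a second chlorine or its changed place on that ring, so the halogen swap is the nearest guide, and it stayed within the scatter. Compound 4 is therefore expected to give about 60%, within 45% to 78%, a step of a number 1.9 percentage points lower from compound 3 to compound 4 (within the scatter) that is expected to stay within the scatter.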

Compound 4, a percentage reported as activity, at one concentration (the size of the read-out at that concentration, not a potency): 90.3%
For compound 4 the middle estimate is 30.3 percentage points below the measured one; measured number above the stated range.
By their numbers in this assay, from the lowest: compounds 3 and 2 (each within the scatter of the next); then compounds 4 and 1 (each within the scatter of the next).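

Swapping one halogen for another on the aromatic ring held by the ring nitrogen had left the number within the scatter, but the aryl group at this position is not indifferent to every change. In this assay, 3,5-dichlorophenyl in place of 4-chlorophenyl gives a number 28.4 percentage points higher from compound 3 to compound 4 (beyond the scatter) and thus a weaker effect, and the comparison with 4-bromophenyl agrees, with a number 23.9 percentage points higher from compound 2 to compound 4 (beyond the scatter). Nothing available explains this weakening. Still open, going by these compounds, is whether the added chlorine or the changed place on the ring matters, and how a methoxy group or an amine there would compare.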